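A few compounds are considered here, and "the series" means these few. Any claim that something is new, unique, unknown or untested is made for them only; others in the source may bear on it.

Measured so far:
compound 1 `Nc1nc(NC2CCCCC2)c2ncn(/C=C3/CC3(CO)CO)c2n1`: "not determined" (no result reported)
compound 2 `CCCCNc1nc(N)nc2c1ncn2/C=C1/CC1(CO)CO`: > 20000 nM

In an ADME assay on MOLT-3 cells (Homo sapiens) for cytotoxicity, with a stated time of 7 days (on this read-out lower numbers stand for higher toxicity in this test and higher numbers for lower toxicity in this test), compound 1 carries no result, "not determined" (no result reported). Compound 2 in this assay gives only a limit, > 20000 nM, not a number. Compound 2 thus stands at the edge of the measured range, with no single number anywhere in the pair; this is the limit of > 20000 nM in this assay, at which 1 of the 2 values shown sits. Compound 3 `Nc1nc(NC2CCCC2)c2ncn(/C=C3/CC3(CO)CO)c2n1` is the next member: cyclopentyl in place of butyl on a nitrogen on an aromatic ring. Going by the values given here, no step between measured compounds is known. Compound 3 is expected to move little in this assay, a step that the limit leaves unreadable from compound 2 to compound 3, a step of none beyond the scatter. The estimate for compound 3 is 30000 nM, within 10000 nM to 100000 nM.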

Compound 3, half-maximal cytotoxic concentration: > 20000 nM
Compound 3: a limit, no number; the forecaster's own chance of this, stated with the estimate: 80%; the middle value is on the limit's open side.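

Going by these compounds alone, compound 2 and compound 3 each give only a limit in this assay, so no step between them can be read. Left open is whether cyclopentyl in place of butyl shifts cytotoxicity at all.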